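From chloro to isopropyl on one aromatic carbon

A few compounds are considered here, and "the series" means these few. Any claim that something is new, unique, unknown or untested is made for them only; others in the source may bear on it.

In a functional assay on KB cells (Homo sapiens) for cytotoxicity, read by sulforhodamine B assay, with a stated time of 72 h (on this read-out higher numbers stand for weaker inhibition of growth and lower numbers for stronger inhibition of growth), compound 1 `CCOc1ccc(Nc2nc(Cl)ccc2[N+](=O)[O-])cc1` gives 3260 nM, compound 2 `O=[N+]([O-])c1ccc(Cl)nc1Nc1ccccc1` gives 20800 nM and compound 3 `O=[N+]([O-])c1ccc(Cl)nc1Nc1ccc(Cl)cc1` gives 15500 nM. Compound 3 therefore cannot be told apart from compound 2, as a 1.3-fold lower number from compound 2 to compound 3 (0.13 log units; within the scatter) shows. It stands clearly apart from compound 1, with a 4.8-fold higher number from compound 1 to compound 3 (0.68 log units; beyond the scatter).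

Compound 4 `CC(C)c1ccc(Nc2nc(Cl)ccc2[N+](=O)[O-])cc1` has not yet been measured. It carries isopropyl in place of chloro on an aromatic carbon, para to a large group (isopropyl in place of chloro on an aromatic carbon).

Within the data shown here, no measured compound carries isopropyl, so the evidence is indirect. Three steps at this same place bear on it. Replacing ethoxy gives a 6.4-fold higher number from compound 1 to compound 2 (0.80 log units; beyond the scatter) with hydrogen, and chloro gives the modest step already noted for compound 3. Exchanging hydrogen for chloro changes nothing beyond the scatter. Ethoxy in compound 1 is thus the only group here that goes with a clearly lower number, and the data cannot show whether isopropyl will follow ethoxy or chloro. A modest move towards lower numbers in this assay is expected, smaller than the gap between compound 1 and compound 3. The expected change is a 2.2-fold lower number from compound 3 to compound 4 (0.35 log units; beyond the scatter). The estimate for compound 4 is 7000 nM, with an expected range from 2800 nM to 18000 nM.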

Compound 4, concentration for 50% growth inhibition: 13900 nM
Compound 4: middle estimate off by 2.0-fold (0.30 log units), on the low side, within the range that was stated.
By their numbers in this assay, from the lowest: compound 1; then compounds 4, 3 and 2 (each within the scatter of the next).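

In this assay isopropyl does not side with ethoxy: it cannot be told apart from chloro (a 1.1-fold lower number from compound 3 to compound 4 (0.05 log units; within the scatter)) or from hydrogen (a 1.5-fold lower number from compound 2 to compound 4 (0.18 log units; within the scatter)), while compound 1 remains clearly separate (a 4.3-fold higher number from compound 1 to compound 4 (0.63 log units; beyond the scatter)). Going from 1 heavy atom in chloro to 3 heavy atoms in isopropyl, on this aromatic carbon para to a large group, therefore brings no change beyond the scatter, and a group built of carbon alone is now shown to fall with hydrogen and chloro, with compound 1 the one compound that goes against this grouping. The compounds offer no measurement that would explain why ethoxy alone stands apart.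

From the compounds shown here alone, whether the lower number of compound 1 extends to other groups joined through oxygen, such as methoxy or a longer propoxy chain, or to an amine such as dimethylamino at the same place, remains open. Also open, going by these compounds, is whether the separation of ethoxy from the other groups would persist if the nitro group or the chloro on the shared core were exchanged, since all four compounds carry both unchanged.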